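Triazole-linked furanone series: sulfonamide for pentylphenyl

A few compounds are considered here, and "the series" means these few. Any claim that something is new, unique, unknown or untested is made for them only; others in the source may bear on it.

Measured in a functional assay on HepG2 cells (Homo sapiens) for antiproliferative activity, read by MTT assay, with a stated time of 72 h; on this read-out lower numbers stand for stronger inhibition and higher numbers for weaker inhibition:
compound 1, `CCCCCc1ccc(-c2cn(C/C=C3\OC(=O)C(OCc4ccccc4)=C3OCc3ccccc3)nn2)cc1`, > 100000 nM.
compound 2, `CCCCCc1ccc(-c2cn(C[C@H](O)[C@H]3OC(=O)C(OCc4ccccc4)=C3OCc3ccccc3)nn2)cc1`, 7460 nM.
compound 3, `O=C1O/C(=C\Cn2cc(-c3cc(C(F)(F)F)cc(C(F)(F)F)c3)nn2)C(OCc2ccccc2)=C1OCc1ccccc1`, > 100000 nM.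

The value of compound 1 is a limit of the assay, not a number. The value of compound 3 likewise is only a limit. Within the data shown here, compound 2 therefore holds the only number in the set; its two neighbours sit at the limit of > 100000 nM in this assay, at which 2 of the 3 values shown sit.

Compound 4, `O=C1O[C@H]([C@@H](O)Cn2cc(CNS(=O)(=O)c3ccc(Cl)cc3)nn2)C(OCc2ccccc2)=C1OCc1ccccc1`, has not been measured. It differs from compound 2 by (((4-chlorophenyl)sulfonyl)amino)methyl in place of 4-pentylphenyl on an aromatic carbon. Among the measured compounds shown here, no step between two measured compounds is available to calibrate a change of this kind, so the expectation rests on compound 2 alone. The step from compound 2 to compound 4 a 2.7-fold higher number from compound 2 to compound 4 (0.43 log units; beyond the scatter) is expected to run toward weaker inhibition and to exceed the scatter. Compound 4 is estimated at 20000 nM, with a range from 4000 nM to 100000 nM.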

Compound 4, half-maximal inhibitory concentration: 7510 nM
For compound 4 the middle estimate is 2.7-fold (0.43 log units) above the measured one; low and high end bracket the measured number.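

In this assay, the aromatic carbon of the five-membered aromatic ring with 3 nitrogen accepts a very different substituent with no readable change: a 1.0-fold higher number from compound 2 to compound 4 (0.00 log units; within the scatter). At this position, the read-out does not separate 4-pentylphenyl from (((4-chlorophenyl)sulfonyl)amino)methyl, so a number in this range does not depend on the 4-pentylphenyl group. No measured property bears on this step, and no cause can be given for it.

On these data alone, it remains open whether a carboxylic acid or an amine at this position would leave the number unchanged. As far as these compounds go, the effect of replacing the 4-chloro substituent on the sulfonyl-bound ring with a methoxy group is also open.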